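The source may hold more compounds than are shown below. What is called first, only, known or untested is meant among the compounds shown, and "the series" means these compounds.

Measured in an assay on HL-60 cells for agonist activity at vitamin D3 receptor (Homo sapiens), read by microscopy, with a stated time of 96 h; on this read-out lower numbers stand for an effect already at smaller amounts and higher numbers for an effect only at larger amounts of compound: compound 1 `CCn1c(C(=O)N(C)c2ccccc2)ccc1C(CC)(CC)c1ccc(OCC(=O)C(C)(C)C)c(C)c1` gives 18500 nM; compound 2 `CCn1c(C(=O)N(CCC#N)CCC#N)ccc1C(CC)(CC)c1ccc(OCC(=O)C(C)(C)C)c(C)c1` gives 870 nM; compound 3 `CCn1c(C(=O)N(C)c2ccccc2)ccc1C(CC)(CC)c1ccc(OCC(O)C(C)(C)C)c(C)c1` gives 6400 nM.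

Compound 2 differs from compound 1 by a group of 9 heavy atoms (6 carbon, 3 nitrogen; no ring) in place of a group of 8 heavy atoms (7 carbon, 1 nitrogen; one six-membered aromatic ring of carbon only), on a carbonyl carbon, and this change gave a 21-fold lower number from compound 1 to compound 2 (1.33 log units; beyond the scatter). The cores of compound 3 and compound 1 differ by 1-hydroxy-2,2-dimethylpropyl in place of (tert-butyl)carbonyl on a saturated chain carbon bound to an oxygen on an aromatic ring, which gave a 2.9-fold lower number from compound 1 to compound 3 (0.46 log units; beyond the scatter). Compound 4 `CCn1c(C(=O)N(CCC#N)CCC#N)ccc1C(CC)(CC)c1ccc(OCC(O)C(C)(C)C)c(C)c1` has not been measured; it differs from compound 3 by a group of 9 heavy atoms (6 carbon, 3 nitrogen; no ring) in place of a group of 8 heavy atoms (7 carbon, 1 nitrogen; one six-membered aromatic ring of carbon only), on a carbonyl carbon, the same change at the same place as from compound 1 to compound 2. In this assay, among the compounds with values here, the expected step is a 21-fold lower number from compound 3 to compound 4 (1.33 log units; beyond the scatter), close to the earlier one, because a 21-fold lower number from compound 1 to compound 2 (1.33 log units; beyond the scatter) is the only measured instance of this change and the two cores differ only in the group on the chain oxygen. Compound 4 is therefore estimated at 300 nM, expected between 100 nM and 900 nM.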

Compound 4, half-maximal effective concentration: 97 nM
Estimate against measurement, compound 4: 3.1-fold (0.49 log units) above; the measured number lies below the stated range.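

In this assay the change on the carbonyl carbon lowered the number on both cores, with a 66-fold lower number from compound 3 to compound 4 (1.82 log units; beyond the scatter), so its direction carried over, but its size did not: the same change on two cores in this assay, a 21-fold lower number (1.33 log units; beyond the scatter) from compound 1 to compound 2 and a 66-fold lower number (1.82 log units; beyond the scatter) from compound 3 to compound 4, 3.1-fold (0.49 log units) apart, beyond the scatter of two such steps

The change from (tert-butyl)carbonyl to 1-hydroxy-2,2-dimethylpropyl also kept its direction, with a 9.0-fold lower number from compound 2 to compound 4 (0.95 log units; beyond the scatter), and again differed in size: the same change on two cores in this assay, a 2.9-fold lower number (0.46 log units; beyond the scatter) from compound 1 to compound 3 and a 9.0-fold lower number (0.95 log units; beyond the scatter) from compound 2 to compound 4, 3.1-fold (0.49 log units) apart, beyond the scatter of two such steps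

The two changes therefore do not act independently in these four compounds, but the compounds do not show why, or whether this holds on any other core.

Still open, on these data alone, is how the step would run with a diethylamino group or a longer nitrile chain on the carbonyl carbon. Also open, as far as these compounds go, is what a methyl ether or an amine would do in place of the hydroxyl.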